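A few compounds are considered here, and "the series" means these few. Any claim that something is new, unique, unknown or untested is made for them only; others in the source may bear on it.

Measured compounds and their values:
- compound 1 `Cc1n[nH]c2ccc(-c3nc4cnc(N5CCN(C)CC5)cn4c3Nc3ccc(F)cc3)cc12` — in a functional assay on MV4-11 cells (Homo sapiens) for inhibition, with a stated time of 120 h (on this read-out higher numbers stand for weaker inhibition and lower numbers for stronger inhibition), compound 1 gives 32300 nM
- compound 3 `Cc1n[nH]c2ccc(-c3nc4cnc(N5CCN(C)CC5)cn4c3Nc3ccc(Cl)cc3F)cc12` — in this assay compound 3 gives 10400 nM
- compound 2 `COc1ccc(Nc2c(-c3ccc4[nH]nc(C)c4c3)nc3cnc(N4CCN(C)CC4)cn23)cc1` — in this assay compound 2 gives "not determined" (no result reported)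

Compound 3 holds the lowest number of the two values that exist; compound 2 has no number. Among the compounds with values here, the only change with a measured outcome is a 3.1-fold lower number from compound 1 to compound 3 (0.49 log units; beyond the scatter), where a 4-fluorophenyl on the ring nitrogen became a 4-chloro-2-fluorophenyl.

Compound 4 `Cc1n[nH]c2ccc(-c3nc4cnc(N5CCN(C)CC5)cn4c3Nc3ccc(F)cc3Br)cc12` differs from compound 3 by 2-bromo-4-fluorophenyl in place of 4-chloro-2-fluorophenyl on a nitrogen on an aromatic ring. Within the data shown here, both groups carry two halogens on the same kind of ring, so the change in compound 4 is a rearrangement of halogens rather than an addition like the one from compound 1 to compound 3. Among the measured compounds shown here, no measured step shows what swapping the halogen positions does, so no direction can be derived; the expectation is a step within the scatter, a 1.2-fold higher number from compound 3 to compound 4 (0.06 log units; within the scatter). For compound 4 the expected value in this assay is therefore 12000 nM, with a range from 4000 nM to 36000 nM.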

Compound 4, half-maximal inhibitory concentration: 3830 nM
Estimate against measurement, compound 4: 3.1-fold (0.50 log units) above; the measured number lies below the stated range.
By their numbers in this assay, from the lowest: compound 4; then compound 3; then compound 1.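

The phenyl group on the amino nitrogen is more sensitive than its similar halogen content suggests: in this assay, moving to 2-bromo-4-fluorophenyl gives a 2.7-fold lower number from compound 3 to compound 4 (0.43 log units; beyond the scatter), even though both groups have the same number of heavy atoms. Adding a bromo in place of a hydrogen on an aromatic carbon gives an 8.4-fold lower number from compound 1 to compound 4 (0.93 log units; beyond the scatter), a larger change than a 3.1-fold lower number from compound 1 to compound 3 (0.49 log units; beyond the scatter) seen with 4-chloro-2-fluorophenyl. Nothing available explains these differences.

Compound 3 and compound 4 differ in more than one halogen, so the shift cannot be assigned to adding bromo or to removing chloro. From the compounds shown here alone, it also remains open whether 2-chloro-4-fluorophenyl, or a methyl or methoxy group in the place of the bromo, would give a similar number.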